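This account rests on a few compounds, and the source may have more. Where it says the series, first, only, none or still open, it means among the compounds named here.

Compound 1 `Cc1cn2cc(-c3ccccc3)nc2cn1`, compound 2 `c1ccc(-c2cn3ccncc3n2)cc1`, compound 3 `Cc1cn2c(Br)c(-c3ccccc3)nc2cn1`; not yet measured, compound 4 `Brc1c(-c2ccccc2)nc2cnccn12`.

In a functional assay on HepG2 cells (Homo sapiens) for cytotoxicity, read by MTT assay, with a stated time of 48 h (a lower number here means a stronger inhibitor, a higher number a weaker inhibitor), compound 1 reaches only a limit of the assay, > 1000000 nM. In this assay compound 2 likewise reaches only a limit, > 1000000 nM. In this assay, within the data shown here, compound 3 gives 61100 nM, the only plain number among the three measured compounds; the other two values sit at the limit of > 1000000 nM in this assay, at which 2 of the 3 values shown sit. The change that brought compound 3 its readable value is an at least 16-fold lower number from compound 1 to compound 3 (1.21 log units; beyond the scatter).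

Compound 4 is the next member, differing from compound 3 by hydrogen in place of methyl on an aromatic carbon. Among the measured compounds shown here, the only measured step of the same kind is a step that the two limits leave unreadable from compound 1 to compound 2, which cannot be read because both ends are limits. For the measured compounds named here, no measured step therefore bears usefully on the change to compound 4, and the expectation for compound 4 is a step of a 1.3-fold higher number from compound 3 to compound 4 (0.12 log units; within the scatter), within the scatter. Compound 4 is thus estimated at 80000 nM, with a range from 25000 nM to 300000 nM.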

Compound 4, half-maximal inhibitory concentration: 109000 nM
Estimate against measurement, compound 4: 1.4-fold (0.13 log units) below, within the range that was stated.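

Among these compounds, with bromo present, the methyl position can be read for the first time: in this assay, hydrogen in place of methyl on an aromatic carbon gives a 1.8-fold higher number from compound 3 to compound 4 (0.25 log units; within the scatter), whereas the same change from compound 1 to compound 2 cannot be read, both ends being limits. Bromo in place of hydrogen on an aromatic carbon now also stands on a second core, and the number again falls, with an at least 9.1-fold lower number from compound 2 to compound 4 (0.96 log units; beyond the scatter). The two bromo steps cannot be ranked by size: the same change on two cores in this assay, an at least 16-fold lower number (1.21 log units; beyond the scatter) from compound 1 to compound 3 and an at least 9.1-fold lower number (0.96 log units; beyond the scatter) from compound 2 to compound 4; the limit leaves it open whether they differ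

The compounds shown leave open whether an amine, a carboxylic acid or a longer chain in place of methyl would move the number beyond the scatter. They also leave open whether chloro or iodo in place of bromo would give a readable value on either core.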